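The compounds below may be only part of what the source reports. "The series", "measured", "known", "first", "only" and "open" are said of these compounds alone.

Working notes on the series.

Three compounds have numbers in a functional assay on KB cells (Homo sapiens) for cytotoxicity, read by spectrophotometry and crystal violet staining (on this read-out lower numbers stand for stronger inhibition and higher numbers for weaker inhibition), so far. Compound 1 `CO/N=C/c1c(Cl)n(C2O[C@H](CO)[C@@H](O)[C@H]2O)c2cc(Cl)c(Cl)cc12` gives 70000 nM in this assay. Compound 2 `N/C(S)=N/N=C/c1c(Cl)n(C2O[C@H](CO)[C@@H](O)[C@H]2O)c2cc(Cl)c(Cl)cc12` gives 65000 nM. Compound 3 `OC[C@H]1O[C@@H](n2c(Br)nc3cc(Cl)c(Cl)cc32)[C@H](O)[C@@H]1O` gives only a limit of the assay, > 100000 nM, and no number; the limit of > 100000 nM in this assay, at which 1 of the 3 values shown sits, marks where it sits. Among the two numbers shown, compound 2 has the lowest, with compound 1 nearest; the step of a 1.1-fold lower number from compound 1 to compound 2 (0.03 log units; within the scatter) lies within the scatter, so no order between the two can be drawn.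

The next compound, compound 4 `NC(=O)c1c(Cl)n(C2O[C@H](CO)[C@@H](O)[C@H]2O)c2cc(Cl)c(Cl)cc12`, has not been measured. Its change from compound 2 is a group of 3 heavy atoms (1 carbon, 1 nitrogen, 1 oxygen; no ring) in place of a group of 6 heavy atoms (2 carbon, 3 nitrogen, 1 sulfur; no ring), on an aromatic carbon. Among the compounds with values here, the only measured step on the same position is the one from compound 1 to compound 2, which stayed within the scatter although it swapped groups of different size and make-up at that position. On that ground no step beyond the scatter is expected in this assay for the change to the carbamoyl group, but the evidence is a single step and the compound 3 limit shows that the series can also fall out of range. Compound 4 is therefore estimated at 80000 nM, with a range from 30000 nM to 250000 nM, the expected step being a 1.2-fold higher number from compound 2 to compound 4 (0.09 log units; within the scatter).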

Compound 4, half-maximal inhibitory concentration: 45000 nM
The estimate for compound 4 lay 1.8-fold (0.25 log units) above the measured number, and the stated range covers the measured number.
By their numbers in this assay, from the lowest: compounds 4, 2 and 1 (each within the scatter of the next). At a limit, above all of these: compound 3.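

In this assay, within the data shown here, the carbamoyl group is the first group at this aromatic carbon without a double-bonded nitrogen, yet the change leaves a 1.4-fold lower number from compound 2 to compound 4 (0.16 log units; within the scatter), and the same holds for a 1.6-fold lower number from compound 1 to compound 4 (0.19 log units; within the scatter). Compounds 1, 2 and 4 therefore stand level within the scatter, so neither the double-bonded nitrogen nor the larger groups of compound 1 and compound 2 show up as a readable step at this position, though this rests on these three groups alone. Compound 3 differs from the others in more than one place and gives only a limit of the assay, not a number, so it adds no step at this position: the limit of > 100000 nM in this assay, at which 1 of the 4 values shown sits.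

On these data alone, whether any group at this aromatic carbon can move the number beyond the scatter stays open, and a carboxylic acid, an amine or a longer chain there would test this. The compounds shown also leave open whether the chloro group next to this position, or the 3,4-dihydroxy-5-(hydroxymethyl)oxolan-2-yl group, matters to the number, as both stay the same in compounds 1, 2 and 4.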